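Furan-2-yl in Place of 4-Nitrophenyl at the Carbonyl

The source may hold more compounds than are shown below. What is called first, only, known or untested is meant among the compounds shown, and "the series" means these compounds.

Compound 2 `COc1ccc(-c2cc3ccccc3nc2/C=C/C(=O)c2ccc([N+](=O)[O-])cc2)cc1` gives 590 nM in a functional assay on SK-BR-3 cells (Homo sapiens) for antiproliferative activity, read by XTT assay, with a stated time of 72 h (a lower number here means a stronger inhibitor, a higher number a weaker inhibitor), the lowest of the two numbers measured, with compound 1 `COc1ccc(-c2cc3ccccc3nc2/C=C/C(=O)c2ccccc2)cc1` nearest at 700 nM. Compound 3 `COc1ccc(-c2cc3ccccc3nc2/C=C/C(=O)c2ccco2)cc1` carries furan-2-yl in place of 4-nitrophenyl on a carbonyl carbon. Within the data shown here, the only measured step, a 1.2-fold lower number from compound 1 to compound 2 (0.07 log units; within the scatter), also alters the aryl group on that carbonyl carbon and stays within the scatter, so no step beyond the scatter is expected from a 1.2-fold higher number from compound 2 to compound 3 (0.07 log units; within the scatter). Compound 3 is therefore estimated at 700 nM, within a range from 300 nM to 1700 nM.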

Compound 3, half-maximal inhibitory concentration: 640 nM
Beside the measured number, compound 3's estimate is 1.1-fold (0.04 log units) above it; measured number inside the range.
By their numbers in this assay, from the lowest: compounds 2, 3 and 1 (each within the scatter of the next).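

On the carbonyl carbon, a five-membered aromatic ring with one hetero atom now takes the place of the six-membered carbon rings, and in this assay neither new step leaves the scatter (a 1.1-fold higher number from compound 2 to compound 3 (0.04 log units; within the scatter); a 1.1-fold lower number from compound 1 to compound 3 (0.04 log units; within the scatter)). Furan-2-yl, phenyl and 4-nitrophenyl at this place thus give numbers within the scatter of one another, although furan-2-yl is the smallest of the three groups. No evidence is available that bears on this result. The compounds shown leave open whether a group without an aromatic ring on that carbonyl carbon, such as a cyclohexyl or a longer alkyl chain, or an amine or a carboxylic acid on the aryl ring, would move the number beyond the scatter.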